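Methoxy to Chloro: Estimating Compound 4

The source may report more compounds than this note shows. Statements on the series, on what has been measured and on what is new or still open speak of the compounds shown alone.

Three compounds have been measured in a functional assay on HCT-116 cells (Homo sapiens) for antiproliferative activity, read by MTT assay, with a stated time of 72 h; on this read-out lower numbers stand for stronger inhibition and higher numbers for weaker inhibition:

Compound 1, `COc1ncc(-c2ccc3nc(NC(=O)NCCN(C)C)sc3c2)cc1NS(=O)(=O)c1ccc(F)cc1`: 240 nM
Compound 2, `CCN(CC)CCNC(=O)Nc1nc2ccc(-c3cnc(OC)c(NS(=O)(=O)c4ccc(F)cc4)c3)cc2s1`: 300 nM
Compound 3, `COc1ncc(-c2ccc3nc(NC(=O)NC4CC4)sc3c2)cc1NS(=O)(=O)c1ccc(F)cc1`: 470 nM

Compound 3 has the highest number of the three, but its distances to the other two are small: a 2.0-fold higher number from compound 1 to compound 3 (0.29 log units; within the scatter), and a 1.6-fold higher number from compound 2 to compound 3 (0.19 log units; within the scatter). The remaining pair behaves the same way: a 1.3-fold higher number from compound 1 to compound 2 (0.10 log units; within the scatter). All three steps concern the group on the amide-type nitrogen, where 2-(dimethylamino)ethyl, 2-(diethylamino)ethyl and cyclopropyl were compared, and none of them moved the read-out beyond its scatter.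

Compound 4, `O=C(Nc1nc2ccc(-c3cnc(Cl)c(NS(=O)(=O)c4ccc(F)cc4)c3)cc2s1)NC1CC1`, differs from compound 3 in one place: chloro in place of methoxy on an aromatic carbon. Within the data shown here, no measured step touches this change. Among the measured compounds shown here, every step so far varied the group on the amide-type nitrogen, while the methoxy group is shared by compounds 1, 2 and 3, so the measured compounds give no evidence for a shift in either direction when chloro replaces it. With nothing to point one way or the other, the number for compound 4 is expected to stay close to that of compound 3, that is a 1.2-fold higher number from compound 3 to compound 4 (0.07 log units; within the scatter), with a wide range to reflect the lack of precedent. Compound 4 is therefore estimated at 550 nM, between 200 nM and 1600 nM.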

Compound 4, half-maximal inhibitory concentration: 1750 nM
Beside the measured number, compound 4's estimate is 3.2-fold (0.50 log units) below it; the measured number lies above the stated range.
By their numbers in this assay, from the lowest: compounds 1, 2 and 3 (each within the scatter of the next); then compound 4.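

In this assay, among these compounds, the change of methoxy to chloro, on the aromatic carbon next to the ring nitrogen and ortho to the ((4-fluorophenyl)sulfonyl)amino group, gives a 3.7-fold higher number from compound 3 to compound 4 (0.57 log units; beyond the scatter) and so is the only step in this set that lies beyond the scatter. Among the compounds shown here, the three earlier comparisons varied only the group on the amide-type nitrogen and stayed within the scatter, so this pair provides the first sign that the read-out responds to a change at this aromatic position, and here chloro goes with weaker inhibition than methoxy. Nothing in the available data accounts for this shift.

As far as these compounds go, this conclusion rests on a single pair carrying the cyclopropyl group, so it remains open whether chloro would have a similar effect alongside the 2-(dimethylamino)ethyl or 2-(diethylamino)ethyl groups of compounds 1 and 2. It is also unknown how other replacements at this position would compare, such as ethoxy, a methyl group, fluoro or an amine, and whether methoxy is a particularly favourable choice or just one of several that would be tolerated.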